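Swapping the hydrazone aryl group: an unmeasured dimethoxyphenyl analogue

The source may hold more compounds than are shown below. What is called first, only, known or untested is meant among the compounds shown, and "the series" means these compounds.

Measured in a functional assay on NCI-H460 cells (Homo sapiens) for cytotoxicity, read by MTT assay, with a stated time of 72 h; on this read-out lower numbers stand for stronger inhibition and higher numbers for weaker inhibition:
- Compound 1 `CN(C)CCn1cnnc1-c1cc(Oc2ccc(NC(=O)N/N=C/c3ccc(Cl)cc3Cl)cc2F)ccn1` gives 130 nM.
- Compound 2 `CN(C)CCn1cnnc1-c1cc(Oc2ccc(NC(=O)N/N=C/c3c(Cl)cccc3Cl)cc2F)ccn1` gives 350 nM.
- Compound 3 `CN(C)CCn1cnnc1-c1cc(Oc2ccc(NC(=O)N/N=C/c3c[nH]c4ccccc34)cc2F)ccn1` gives 1630 nM.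

Compound 3 stands at the highest number of the three, with compound 2 nearest and compound 1 furthest. Compound 4 `COc1ccc(OC)c(/C=N/NC(=O)Nc2ccc(Oc3ccnc(-c4nncn4CCN(C)C)c3)c(F)c2)c1` differs from compound 3 by 2,5-dimethoxyphenyl in place of 1H-indol-3-yl on a carbon with a double bond to nitrogen. Among the measured compounds shown here, no measured step covers this exact change. The two steps that touch the same position, a 13-fold higher number from compound 1 to compound 3 (1.10 log units; beyond the scatter) and a 4.7-fold higher number from compound 2 to compound 3 (0.67 log units; beyond the scatter), both show the indolyl giving higher numbers than a substituted phenyl. A return to a substituted phenyl in compound 4 is therefore expected to lower the number, a 3.3-fold lower number from compound 3 to compound 4 (0.51 log units; beyond the scatter), though the size is uncertain. Compound 4 is estimated at 500 nM, within a range from 150 nM to 1700 nM.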

Compound 4, half-maximal inhibitory concentration: 2930 nM
Estimate against measurement, compound 4: 5.9-fold (0.77 log units) below; the whole stated range lies below it.
By their numbers in this assay, from the lowest: compound 1; then compound 2; then compounds 3 and 4 (each within the scatter of the next).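

In this assay, the change shows a 1.8-fold higher number from compound 3 to compound 4 (0.25 log units; within the scatter), so the 2,5-dimethoxyphenyl and the 1H-indol-3-yl cannot be told apart at this position. A phenyl ring alone therefore does not bring the lower numbers: the dichlorophenyl compounds stand clear of compound 4, with an 8.4-fold higher number from compound 2 to compound 4 (0.92 log units; beyond the scatter) and a 23-fold higher number from compound 1 to compound 4 (1.35 log units; beyond the scatter), so what the ring carries matters. Nothing measured here explains this difference. The compounds shown leave open how a plain phenyl, or a phenyl carrying a single chlorine, an amine or a carboxylic acid, would read at this position.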